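This account rests on a few compounds, and the source may have more. Where it says the series, first, only, none or still open, it means among the compounds named here.

Measured so far in a physicochemical assay for solubility, in phosphate buffer, at pH 7.4; on this read-out higher numbers stand for higher solubility and lower numbers for lower solubility:
compound 1 `CCOC(=O)c1c(-c2cccc([N+](=O)[O-])c2)[nH]c2cccc(OC)c2c1=O` gives 49000 nM
compound 2 `CCOC(=O)c1c(-c2ccc(Cl)cc2)[nH]c2cc(OC)ccc2c1=O` gives 3000 nM
compound 3 `CCOC(=O)c1c(-c2ccc(C(C)(C)C)cc2)[nH]c2cc(OC)ccc2c1=O` gives 2000 nM

Compound 2 stands second highest of these three numbers in this assay. Its nearest neighbour is compound 3, reached by a 1.5-fold lower number from compound 2 to compound 3 (0.18 log units; within the scatter), a step within the scatter. Compound 1 lies furthest off, its number higher than that of compound 2 by a margin beyond the scatter; no single step is shown between those two. Compound 4 `CCOC(=O)c1c(-c2ccccc2Cl)[nH]c2cc(OC)ccc2c1=O` has not been measured. The change from compound 2 is 2-chlorophenyl in place of 4-chlorophenyl on an aromatic carbon. Among the measured compounds shown here, the only measured step touching the 4-chlorophenyl group, a 1.5-fold lower number from compound 2 to compound 3 (0.18 log units; within the scatter), replaces the chloro group rather than relocating it, so no measured step bears directly on this change. The expected step is therefore a 1.3-fold higher number from compound 2 to compound 4 (0.12 log units; within the scatter), not beyond the scatter. For compound 4 the estimate in this assay is 4000 nM, between 1500 nM and 10000 nM.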

Compound 4, solubility: 28000 nM
Beside the measured number, compound 4's estimate is 7.0-fold (0.85 log units) below it, and the stated range ends below it.
By their numbers in this assay, from the lowest: compounds 3 and 2 (each within the scatter of the next); then compounds 4 and 1 (each within the scatter of the next).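

In this assay, relocating the chlorine alone, with the atoms unchanged, gives (a 9.3-fold higher number from compound 2 to compound 4 (0.97 log units; beyond the scatter)), whereas replacing chloro with tert-butyl on the 4-substituted phenyl gives (a 1.5-fold lower number from compound 2 to compound 3 (0.18 log units; within the scatter)). On this aromatic carbon, the place of the chlorine on the phenyl group therefore matters, which the earlier step could not show. Nothing available accounts for the size of this step.

From the compounds shown here alone, whether a 2-methylphenyl or 2-methoxyphenyl group would follow the 2-chlorophenyl group remains open. So does the outcome with a 3-chlorophenyl group, or with an amine or carboxylic acid on this phenyl ring.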